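The compounds below may be only part of what the source reports. "The series", "measured", "known", "first", "only" and "open" are said of these compounds alone.

Working notes on the series. Compound 1 `CO[C@H]1CC[C@H](CN2C(=O)CNc3ncc(-c4ccc(-c5nc[nH]n5)nc4C)nc32)CC1` gives 142 nM in a functional assay on PC-3 cells (Homo sapiens) for inhibition, with a stated time of 72 h (a lower number here means a stronger inhibitor, a higher number a weaker inhibitor), and stands highest of the two numbers, its nearest neighbour being compound 2 `COCCN1C(=O)CNc2ncc(-c3ccc(-c4nc[nH]n4)nc3C)nc21` at 137 nM, with a 1.0-fold lower number from compound 1 to compound 2 (0.02 log units; within the scatter). Compound 3 `CO[C@H]1CC[C@H](N2C(=O)CNc3ncc(-c4ccc(-c5nc[nH]n5)nc4C)nc32)CC1` differs from compound 1 by 4-methoxycyclohexyl in place of (4-methoxycyclohexyl)methyl on an amide-type nitrogen in a ring. Within the data shown here, the only measured step at this position is the one from compound 1 to compound 2, which stays within the scatter, so changes on this ring nitrogen appear tolerated there; no measured step removes a single chain carbon in this way. For compound 3 the expected step is a 1.1-fold higher number from compound 1 to compound 3 (0.05 log units; within the scatter), no more than the scatter. The estimate for compound 3 is 160 nM, in the range 60 nM to 420 nM.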

Compound 3, half-maximal inhibitory concentration: 38 nM
The estimate for compound 3 lay 4.2-fold (0.62 log units) above the measured number; measured number outside the range, below it.
By their numbers in this assay, from the lowest: compound 3; then compounds 2 and 1 (each within the scatter of the next).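

In this assay, 4-methoxycyclohexyl placed directly on the amide-type ring nitrogen gives a change beyond the scatter, a 3.7-fold lower number from compound 1 to compound 3 (0.57 log units; beyond the scatter), so this position is not as tolerant as the earlier within-scatter step suggested. Replacing 2-methoxyethyl with the same group also goes beyond the scatter, a 3.6-fold lower number from compound 2 to compound 3 (0.56 log units; beyond the scatter), and compound 3 has the lowest number of the three. No measurement on hand bears on the reason for this difference.

Going by these compounds, it remains open whether the methoxy group is needed, as a plain cyclohexyl or a 4-hydroxycyclohexyl on this nitrogen would show. A piperidine ring or a morpholine ring there would test whether the carbon-only ring is required.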